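This account rests on a few compounds, and the source may have more. Where it says the series, first, only, none or still open, it means among the compounds named here.

Of the compounds shown here, three built on the shared core have been tested in a functional assay on SGC-7901 cells (Homo sapiens) for antiproliferative activity, read by MTT assay, with a stated time of 72 h; a higher number here means a weaker inhibitor, a lower number a stronger inhibitor. Compound 1 `COc1cc(-c2ccc3ncn(-c4cc(OC)c(OC)c(OC)c4)c3c2)cc(OC)c1OC` reaches only a limit of the measurement, > 10000 nM, rather than a number (the limit of > 10000 nM in this assay, at which 1 of the 3 values shown sits). Compound 2 `COc1cc(-n2cnc3ccc(-c4ccccc4)cc32)cc(OC)c1OC` gives 290 nM. Compound 3 `COc1cc(-n2cnc3ccc(-c4cccc([N+](=O)[O-])c4)cc32)cc(OC)c1OC` gives 380 nM, and the step of a 1.3-fold higher number from compound 2 to compound 3 (0.12 log units; within the scatter) lies within the usual scatter, so the numbers of these two compounds are not told apart. The next compound, compound 4 `COc1ccc(-c2ccc3ncn(-c4cc(OC)c(OC)c(OC)c4)c3c2)cc1O`, differs from compound 3 in one place: 3-hydroxy-4-methoxyphenyl in place of 3-nitrophenyl on an aromatic carbon. Within the data shown here, the only measured step that touches this place is a 1.3-fold higher number from compound 2 to compound 3 (0.12 log units; within the scatter), which swapped hydrogen for nitro without moving the number beyond the scatter; no measured step covers a hydroxy or a methoxy group here, so the direction of the change rests on little. The expectation is a modest move to a lower number, a 2.5-fold lower number from compound 3 to compound 4 (0.40 log units; beyond the scatter), carried with wide uncertainty. Compound 4 is therefore estimated at 150 nM, within a range from 30 nM to 800 nM.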

Compound 4, half-maximal inhibitory concentration: 44 nM
The estimate for compound 4 lay 3.4-fold (0.53 log units) above the measured number; measured number inside the range.
By their numbers in this assay, from the lowest: compound 4; then compounds 2 and 3 (each within the scatter of the next). At a limit, above all of these: compound 1.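

In this assay, the nitro group had left the number within the scatter, so this position on the aromatic carbon seemed to respond little to what the phenyl ring carries. The 3-hydroxy-4-methoxyphenyl group shows otherwise, with an 8.6-fold lower number from compound 3 to compound 4 (0.94 log units; beyond the scatter) and a 6.6-fold lower number from compound 2 to compound 4 (0.82 log units; beyond the scatter), so the substituents on this ring can clearly move the number. Compound 1, which differs from compound 4 only at this place, stands at a limit of the assay rather than at a number: the limit of > 10000 nM in this assay, at which 1 of the 4 values shown sits.

The hydroxy and the methoxy enter together, so the compounds shown cannot say which of the two carries the gain, or whether it takes both. Also open, going by these compounds, is whether an amine in place of the hydroxy, or a longer chain such as ethoxy in place of the methoxy, would keep the number this low.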